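The source may hold more compounds than are shown below. What is called first, only, known or untested is meant among the compounds shown, and "the series" means these compounds.

The measured compounds:

- Compound 1, `O=C(Nc1ccc(Oc2ccccc2)cc1)Oc1ccccc1F`: in an assay on H4 cells for inhibition of Fatty-acid amide hydrolase 1 (Homo sapiens) (a lower number here means a stronger inhibitor, a higher number a weaker inhibitor), compound 1 gives 1300 nM.
- Compound 2, `CCCCOc1ccc(NC(=O)Oc2ccccc2F)cc1`: in this assay compound 2 gives 340 nM.
- Compound 3, `CCCCOc1ccc(C(CC)NC(=O)Oc2ccccc2F)cc1`: in this assay compound 3 gives 7.7 nM.

Compound 3 stands lowest of the three numbers. Its nearest neighbour is compound 2, whose value is well beyond the scatter above it, and compound 1 lies further still. Among the measured pairs only one step is counted: a 3.8-fold lower number from compound 1 to compound 2 (0.58 log units; beyond the scatter), a modest gain that concerns the group on the oxygen of the aromatic ring, not the carbamate end of the molecule.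

Compound 4, `CCCCOc1ccc(C(CC)NC(=O)Oc2ccc(OC)cc2)cc1`, differs from compound 3 at that other end: 4-methoxyphenyl in place of 2-fluorophenyl on an oxygen next to a carbonyl group. Within the data shown here, no measured step touches this part of the structure, so the expectation cannot be read off a precedent and rests on the value of compound 3 alone. With that caveat, the step of a 2.6-fold higher number from compound 3 to compound 4 (0.41 log units; beyond the scatter) is expected to be small, most likely a loss that stays close to the scatter. Compound 4 is therefore estimated at 20 nM in this assay, within a range from 4 nM to 100 nM.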

Compound 4, half-maximal inhibitory concentration: 12 nM
The estimate for compound 4 lay 1.7-fold (0.22 log units) above the measured number, within the range that was stated.
By their numbers in this assay, from the lowest: compounds 3 and 4 (each within the scatter of the next); then compound 2; then compound 1.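

In this assay, among these compounds, the exchange of 2-fluorophenyl for 4-methoxyphenyl on an oxygen next to a carbonyl group gives a 1.6-fold higher number from compound 3 to compound 4 (0.19 log units; within the scatter), the first look at this end of the molecule, since the only earlier step concerned the group on the oxygen at the opposite end. For this one pair, the 2-fluorophenyl group can therefore be replaced without a change that stands out from the scatter, even though the entering group brings one more heavy atom and a hydrogen-bond acceptor by the count. Nothing shown here explains why the two compounds read alike.

The compounds shown leave open whether a longer chain in place of the methoxy group, or an amine or a carboxylic acid on this phenyl ring, would keep the number in the same range, and a single pair cannot show a trend for this position. As far as these compounds go, it also remains open whether the same exchange would read alike on the core of compound 2 or the core of compound 1.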